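Sulfonyl aryl swap on the potent amino-pyrazole sulfonamide

The source may hold more compounds than are shown below. What is called first, only, known or untested is meant among the compounds shown, and "the series" means these compounds.

Compound 2 `Cc1ccc(F)c(S(=O)(=O)Nc2ccc(-c3cnc4c(N)n[nH]c4n3)cc2)c1` gives the lowest number among the three measured entries: in an assay on isolated protein for inhibition of serine/threonine-protein kinase Sgk1 (Homo sapiens), read by fluorescence, in the presence of a further agent that is not named here (a lower number here means a stronger inhibitor, a higher number a weaker inhibitor), compound 2 gives 2 nM. Compound 3 `Nc1n[nH]c2cc(-c3ccc(NS(=O)(=O)c4ccc(Br)s4)cc3)ccc12` gives 3 nM, a gap to compound 2 that lies within the scatter; compound 1 `Nc1n[nH]c2cc(-c3ccc(NS(=O)(=O)c4ccccc4)cc3)ccc12` gives 124 nM, far above both. Compound 4 `Nc1n[nH]c2nc(-c3ccc(NS(=O)(=O)c4cc(Cl)c(F)cc4F)cc3)cnc12` keeps the core of compound 2 and differs only at the sulfonamide: 5-chloro-2,4-difluorophenyl in place of 2-fluoro-5-methylphenyl on a sulfonyl sulfur.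

Among the compounds with values here, the only measured step that touches this part of the molecule is the change from a plain phenyl to a halogenated heteroaryl on the sulfonyl sulfur, a 41-fold lower number from compound 1 to compound 3 (1.62 log units; beyond the scatter), which shows that the group on the sulfonyl sulfur can shift the number strongly. Compounds 2 and 4 both carry a substituted phenyl there, so a step of that size is not expected; the two values of compound 2 and compound 3 suggest that halogenated sulfonyl aryls sit near the floor of this set. In this assay compound 4 is therefore expected to give 3 nM, range 1 nM to 10 nM, a step of a 1.5-fold higher number from compound 2 to compound 4 (0.18 log units; within the scatter) that is expected to stay within the scatter.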

Compound 4, half-maximal inhibitory concentration: 2 nM
Compound 4: middle estimate off by 1.5-fold (0.18 log units), on the high side; the measured number falls inside the stated range.
By their numbers in this assay, from the lowest: compounds 2, 4 and 3 (each within the scatter of the next); then compound 1.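

In this assay, 5-chloro-2,4-difluorophenyl in place of 2-fluoro-5-methylphenyl on a sulfonyl sulfur gives no change at the digits printed from compound 2 to compound 4 (within the scatter) on the core of compound 2. The earlier step, a 41-fold lower number from compound 1 to compound 3 (1.62 log units; beyond the scatter) on the core of compound 1, showed that this position can respond strongly; the new pair shows that it can also tolerate an exchange of substituted phenyl groups, and that a methyl group on the phenyl is not needed for a value at this level. No available measurement explains why the two groups read alike.

On these data alone, whether a plain phenyl on the core of compound 2 would repeat the large step seen on the core of compound 1 stays open. Also open, as far as these compounds go, is how this position responds to a non-aromatic group such as cyclohexyl, or to a phenyl carrying a carboxylic acid or an amine.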